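Methyl removed from the nitrogen: expectation for compound 4

A few compounds are considered here, and "the series" means these few. Any claim that something is new, unique, unknown or untested is made for them only; others in the source may bear on it.

Measured so far in a functional assay on HCT-116 cells (Homo sapiens) for inhibition, read by MTT assay, with a stated time of 72 h, tested at 20 uM; a higher number here means more inhibition at the concentration tested (going by the name of the read-out), a lower number less inhibition:
compound 1, `CN(c1ccc(Oc2ncnc3ccsc23)cc1)c1nccc(N2CCCC2)n1`: 63.6%
compound 2, `CN(c1ccc(Oc2ncnc3ccsc23)cc1)c1nccc(N2CCc3ccccc3C2)n1`: 58.3%
compound 3, `CN(c1ccc(Oc2ncnc3ccsc23)cc1)c1nccc(N2CCc3ccccc32)n1`: 57.8%

Compound 2 stands second of the three numbers in this assay. Its nearest neighbour is compound 3, with a number 0.5 percentage points lower from compound 2 to compound 3 (within the scatter), and the furthest is compound 1, with a number 5.3 percentage points lower from compound 1 to compound 2 (within the scatter); the remaining pair gives a number 5.8 percentage points lower from compound 1 to compound 3 (within the scatter). All three steps stay inside the scatter, so the three measured compounds cannot be ranked against each other on these data.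

Compound 4, `c1ccc2c(c1)CCN(c1ccnc(Nc3ccc(Oc4ncnc5ccsc45)cc3)n1)C2`, is the next compound to be measured. It differs from compound 2 in one place: hydrogen in place of methyl on a nitrogen on an aromatic ring. Going by the values given here, none of the measured steps touches this nitrogen; each of them exchanges the ring on the aromatic carbon while the methyl on the nitrogen is kept, and each is within the scatter. Among the compounds with values here, there is therefore no measured step that bears on the change from compound 2 to compound 4, and no ground for expecting a move beyond the scatter in either direction. The step to compound 4 is expected to be a number 1.3 percentage points lower from compound 2 to compound 4 (within the scatter). On that basis compound 4 is estimated at 57% in this assay, with a range from 40% to 74%.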

Compound 4, a percentage reported as inhibition, at one concentration (the size of the read-out at that concentration, not a potency): 40.9%
Estimate against measurement, compound 4: 16.1 percentage points above; the measured number falls inside the stated range.
By their numbers in this assay, from the lowest: compound 4; then compounds 3, 2 and 1 (each within the scatter of the next).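

In this assay, going by these compounds alone, the nitrogen on an aromatic ring is the first place where a single change goes beyond the scatter: with hydrogen in place of methyl there is a number 17.4 percentage points lower from compound 2 to compound 4 (beyond the scatter). The earlier steps all exchanged the ring on the aromatic carbon with the methyl kept, and none of them separated the compounds, so among the compounds shown this nitrogen matters more to the read-out than that ring, although the claim rests on a single pair carrying 1,2,3,4-tetrahydroisoquinolin-2-yl. No measurement at hand speaks to the reason for this drop in inhibition.

Open, as far as these compounds go, is whether hydrogen in place of methyl gives a step of similar size when the ring on the aromatic carbon is pyrrolidin-1-yl, as in compound 1, or 2,3-dihydro-1H-indol-1-yl, as in compound 3. Also open is how an ethyl group, a longer alkyl chain or an acetyl group on that nitrogen would read in this assay, with methyl and hydrogen the only two substituents shown there so far.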